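Bromo for cyano on the aryl ketone of compound 3

A few compounds are considered here, and "the series" means these few. Any claim that something is new, unique, unknown or untested is made for them only; others in the source may bear on it.

Measured compounds in a functional assay on DU-145 cells (Homo sapiens) for inhibition, read by trypan blue exclusion, with a stated time of 96 h; on this read-out lower numbers stand for stronger inhibition of growth and higher numbers for weaker inhibition of growth:
Compound 1 `O=C(/C(=C\c1ccc(O)c([N+](=O)[O-])c1)SCc1ccc(Br)cc1)c1c(F)c(F)c(F)c(F)c1F` gives 10000 nM.
Compound 2 `O=C(/C(=C\c1ccc(O)c(C(=O)O)c1)SCc1ccc(Br)cc1)c1ccc(Br)cc1` gives 10000 nM.
Compound 3 `N#Cc1ccc(C(=O)/C(=C\c2ccc(O)c([N+](=O)[O-])c2)SCc2ccc(Br)cc2)cc1` gives 10000 nM.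

Compound 3 stands level with compounds 1 and 2 at the digits shown: its nearest neighbour is compound 1, and the step of no change at the digits printed from compound 1 to compound 3 (within the scatter) shows no change within the scatter. Compound 2, which already carries a 4-bromophenyl on the carbonyl carbon, sits at the same reading, and so does compound 1 with its pentafluorophenyl there.

Compound 4 `O=C(/C(=C\c1ccc(O)c([N+](=O)[O-])c1)SCc1ccc(Br)cc1)c1ccc(Br)cc1` is not yet measured. It differs from compound 3 in one place: bromo in place of cyano on an aromatic carbon. Going by the values given here, the one step that bears on this site, from compound 1 to compound 3, changed nothing, and compound 2 shows that a 4-bromophenyl on the carbonyl carbon gives the same reading as the other aryl groups. Nothing here points to any step beyond the scatter in this assay in either direction. Compound 4 is therefore expected to give 10000 nM, within 5000 nM to 20000 nM. The step of no change at the digits printed from compound 3 to compound 4 (within the scatter) is expected to be nil within the scatter.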

Compound 4, concentration for 50% growth inhibition: 10000 nM
Compound 4: the middle estimate sits on the measured number at the digits printed; low and high end bracket the measured number.
By their numbers in this assay, from the lowest: compounds 1, 2, 3 and 4 (each within the scatter of the next).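

With bromo in place of cyano, the aryl ketone position shows no response in this assay (no change at the digits printed from compound 3 to compound 4 (within the scatter)). Compound 4 extends this to the pentafluorophenyl comparison, so three aryl groups on the carbonyl carbon now read alike with the nitro group held constant (no change at the digits printed from compound 1 to compound 4 (within the scatter)). It also supplies the first pair differing at the other aromatic site, where nitro in place of carboxy leaves the reading unmoved (no change at the digits printed from compound 2 to compound 4 (within the scatter)).

Going by these compounds, whether an amine, a carboxylic acid or a longer chain on the aryl ketone would separate from this shared reading remains open, as does whether any change at all can move the value in this assay. No supporting evidence is available to explain why these readings coincide.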